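Swapping the Carbamate Aryl Group on the Geranyl-Chain Core

This account rests on a few compounds, and the source may have more. Where it says the series, first, only, none or still open, it means among the compounds named here.

Compound 1 `CC(C)=CCC/C(C)=C/CC1Cc2c(O)cc(=O)n(CCCO)c2CC1(C)C`: in a functional assay on PANC-1 cells (Homo sapiens) for inhibition, read by MTT assay, with a stated time of 24 h, tested at 10 uM (a lower number here means less inhibition, a higher number more inhibition at the concentration tested (going by the name of the read-out)), compound 1 gives 28.7%.
Compound 2 `CC(C)=CCC1Cc2c(OC(=O)Nc3ccc(F)cc3F)cc(=O)n(CCCO)c2CC1(C)C`: compound 2 gives 69.7%.
Compound 3 `COc1cccc(NC(=O)Oc2cc(=O)n(CCCO)c3c2CC(C/C=C(\C)CCC=C(C)C)C(C)(C)C3)c1`: compound 3 gives 47%.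

Compound 3 stands second highest of the three numbers, beyond the scatter above compound 1 and beyond the scatter below compound 2. Within the data shown here, the one measured step that touches the carbamate is a number 18.3 percentage points higher from compound 1 to compound 3 (beyond the scatter), which installs the carbamate rather than exchanging its aryl group. Compound 4 `CC(C)=CCC/C(C)=C/CC1Cc2c(OC(=O)Nc3ccc(F)cc3F)cc(=O)n(CCCO)c2CC1(C)C` differs from compound 3 by 2,4-difluorophenyl in place of 3-methoxyphenyl on an amide-type nitrogen. Among the measured compounds shown here, no measured pair isolates this exchange; compound 2, which carries the same 2,4-difluorophenyl carbamate on a shorter chain, holds the highest value. The author therefore expects a modest rise, a number 11 percentage points higher from compound 3 to compound 4 (beyond the scatter), and estimates compound 4 at 58%, within 40% to 75%.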

Compound 4, a percentage reported as inhibition, at one concentration (the size of the read-out at that concentration, not a potency): 33.7%
Compound 4: the middle estimate sits 24.3 percentage points above what was measured, and the stated range ends above it.
By their numbers in this assay, from the lowest: compounds 1 and 4 (each within the scatter of the next); then compound 3; then compound 2.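

In this assay the aryl group on the amide-type nitrogen proves to matter on this chain, as 2,4-difluorophenyl in place of 3-methoxyphenyl gives a number 13.3 percentage points lower from compound 3 to compound 4 (beyond the scatter) in this pair. With the (2,4-difluorophenyl)carbamoyl group on the oxygen, the step is a number 5 percentage points higher from compound 1 to compound 4 (within the scatter) here, so this carbamate, unlike the (3-methoxyphenyl)carbamoyl group, adds no change beyond the scatter. The chain also counts, with a number 36 percentage points lower from compound 2 to compound 4 (beyond the scatter) on adding the 3-methylbut-2-en-1-yl group. Going by these compounds, how 3-methoxyphenyl would read on the shorter chain, or a plain phenyl or pyridin-3-yl on that nitrogen, stays open. No measurement at hand explains these steps.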